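The source may hold more compounds than are shown below. What is called first, only, known or untested is meant among the compounds shown, and "the series" means these compounds.

Working notes on the series. Three compounds are measured: compound 1 `O=C1N(CCCCCCOc2ccc(Br)cc2)CCN1c1ccncc1`, compound 2 `Cc1ccc(OCCCCCCN2CCN(c3ccncc3)C2=O)cc1` and compound 3 `CN(C)c1cccc(OCCCCCCN2CCN(c3ccncc3)C2=O)c1`. They share one core and differ only in the aryl group on the oxygen of the saturated chain. In a functional assay on cells (Homo sapiens) for cytotoxicity (on this read-out lower numbers stand for higher toxicity in this test and higher numbers for lower toxicity in this test), compound 1 gives > 25000 nM, which is a limit of the assay and not a number. In this assay compound 2 likewise reaches only a limit, > 25000 nM. Compound 3 stands at the same place: in this assay its result is the limit > 25000 nM. Accordingly the steps a step that the two limits leave unreadable from compound 1 to compound 2, a step that the two limits leave unreadable from compound 1 to compound 3 and a step that the two limits leave unreadable from compound 2 to compound 3 cannot be sized; the whole of the evidence is the limit of > 25000 nM in this assay, at which 3 of the 3 values shown sit.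

Compound 4 `COc1ccc(OCCCCCCN2CCN(c3ccncc3)C2=O)c(Cl)c1` is not yet measured. The change from compound 3 is 2-chloro-4-methoxyphenyl in place of 3-(dimethylamino)phenyl on an oxygen on a saturated carbon, an exchange of one aryl group for another with the same heavy-atom count and the same count of donors and acceptors. For the measured compounds named here, every measured exchange of this aryl group left the read-out at the limit in this assay, so no step of readable size bears on the new one, and no shift beyond the scatter is expected. Compound 4 is therefore expected to stay at the limit in this assay, with an estimated step that the limit leaves unreadable from compound 3 to compound 4. The estimate for compound 4 is 30000 nM, within a range of 15000 nM to 80000 nM.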

Compound 4, half-maximal cytotoxic concentration: > 25000 nM
Compound 4 gave a limit, no number (the forecaster's own chance of this, stated with the estimate: 80%); the middle value lies beyond the limit too.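

No step can be read between compound 4 and compound 1, compound 2 or compound 3 in this assay, where each result is a limit and not a number: the limit of > 25000 nM in this assay, at which 4 of the 4 values shown sit.

The compounds shown leave open where the actual values lie, and whether any aryl group on the oxygen of the chain gives a readable number in this assay.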